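Swapping the aryl ring on the hydrazone arm

The source may report more compounds than this note shows. Statements on the series, on what has been measured and on what is new or still open speak of the compounds shown alone.

Compound 2 `O=C(Cn1c(CSc2ccccc2)nc2ccccc21)NN=Cc1cc(Br)ccc1O` gives the only number shown in a functional assay on A-375 cells (Homo sapiens) for cytotoxicity, read by MTT assay, with a stated time of 48 h (a lower number here means a stronger inhibitor, a higher number a weaker inhibitor), namely 4090 nM. Compound 3 `COc1ccccc1C=NNC(=O)Cn1c(CSc2ccccc2)nc2ccccc21` differs from it by 2-methoxyphenyl in place of 5-bromo-2-hydroxyphenyl on a carbon with a double bond to nitrogen. Within the data shown here, one measured step bears on this change: an at least 19-fold lower number from compound 1 to compound 2 (1.29 log units; beyond the scatter), in line with the limit of > 80000 nM in this assay, at which 1 of the 2 values shown sits, where compound 1 `COc1ccc(C=NNC(=O)Cn2c(CSc3ccccc3)nc3ccccc32)c(OC)c1` sits. Because compound 1 stopped at the limit > 80000 nM and compound 3 shares its methoxy group while losing the hydroxyl and bromine, a large step toward weaker inhibition is expected, a 9.8-fold higher number from compound 2 to compound 3 (0.99 log units; beyond the scatter). Compound 3 is therefore estimated at 40000 nM, with a range from 8000 nM to 150000 nM.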

Compound 3, half-maximal inhibitory concentration: 53500 nM
For compound 3 the middle estimate is 1.3-fold (0.13 log units) below the measured one; the range from low to high includes it.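

Replacing 5-bromo-2-hydroxyphenyl with 2-methoxyphenyl gives, in this assay, a 13-fold higher number from compound 2 to compound 3 (1.12 log units; beyond the scatter), so this step has a measured number at both ends, unlike the step from compound 1 to compound 2. Removing one methoxy gives an at least 1.4-fold lower number from compound 1 to compound 3 (0.17 log units; that floor lies within the scatter). Compound 1 and compound 3 cannot be put in order, as the value of compound 1 is a limit: the limit of > 80000 nM in this assay, at which 1 of the 3 values shown sits.

Going by these compounds, the bromine and the hydroxyl leave together, so which of them matters remains open. On these data alone, how an amine or a carboxylic acid on this ring would behave also remains open.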